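A few compounds are considered here, and "the series" means these few. Any claim that something is new, unique, unknown or untested is made for them only; others in the source may bear on it.

Measured compounds:
Compound 1, `Cc1ncnc2c1c(I)cn2[C@@H]1O[C@H](CO)[C@@H](O)[C@H]1O`, gives 3460 nM in a functional assay on HepG2 cells (Homo sapiens) for antiproliferative activity, read by XTT assay, with a stated time of 72 h; a higher number here means a weaker inhibitor, a lower number a stronger inhibitor.
Compound 2, `Cc1ncnc2c1c(-c1ccoc1)cn2[C@@H]1O[C@H](CO)[C@@H](O)[C@H]1O`, gives 5320 nM in this assay.
Compound 3, `Cc1nc(N)c2c(I)cn([C@@H]3O[C@H](CO)[C@@H](O)[C@H]3O)c2n1`, gives 6310 nM in this assay.

From compound 1 to compound 2 the change is furan-3-yl in place of iodo on an aromatic carbon, and in this assay it gave a 1.5-fold higher number from compound 1 to compound 2 (0.19 log units; within the scatter). Compound 3 carries a different core from compound 1; the difference between the two cores is not broken down here. Compound 4, `Cc1nc(N)c2c(-c3ccoc3)cn([C@@H]3O[C@H](CO)[C@@H](O)[C@H]3O)c2n1`, is derived from compound 3 by furan-3-yl in place of iodo on an aromatic carbon, the same change at the same kind of place as from compound 1 to compound 2. Since that earlier step gave a 1.5-fold higher number from compound 1 to compound 2 (0.19 log units; within the scatter), the expected step in this assay is a 1.4-fold higher number from compound 3 to compound 4 (0.15 log units; within the scatter). Compound 4 is therefore estimated at 9000 nM, with a likely range from 3500 nM to 25000 nM.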

Compound 4, half-maximal inhibitory concentration: > 20000 nM
Compound 4: no number, only a limit; the forecaster's own chance of this, stated with the estimate: 10%; at least 2.2-fold (0.34 log units) between middle value and limit.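

In this assay compound 4 gives > 20000 nM as a limit of the assay and not as a number. On the core of compound 3, furan-3-yl in place of iodo gave an at least 3.1-fold higher number from compound 3 to compound 4 (0.50 log units; beyond the scatter) and on the core of compound 1 the same change gave a 1.5-fold higher number from compound 1 to compound 2 (0.19 log units; within the scatter) as the earlier step. This shows a step beyond the scatter on one core only, and it does not show that the change truly acts differently on the two cores: the same change on two cores in this assay, a 1.5-fold higher number (0.19 log units; within the scatter) from compound 1 to compound 2 and an at least 3.1-fold higher number (0.50 log units; beyond the scatter) from compound 3 to compound 4; the limit leaves it open whether they differ.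

The compounds shown leave open how an amine, a carboxylic acid or a longer chain in place of iodo would behave on either core. They also leave open how the change would carry to any further core.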